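The source may hold more compounds than are shown below. What is called first, only, known or untested is meant among the compounds shown, and "the series" means these compounds.

Working notes on the benzothiazole-amide series.

Compound 1 `Cc1cc(C)c2sc(NC(=O)c3ccc(C#N)cc3)nc2c1` and compound 2 `Cc1cc(C)c2sc(NC(=O)c3ccc(C(F)(F)F)cc3)nc2c1` share one core and differ only in the group on the benzamide ring. In a functional assay on NUGC-3 cells (Homo sapiens) for antiproliferative activity, read by sulforhodamine B assay (on this read-out higher numbers stand for weaker inhibition of growth and lower numbers for stronger inhibition of growth), compound 1 gives 0.62 ug/mL, and compound 2 gives 1.4 ug/mL. The step between them, a 2.3-fold lower number from compound 2 to compound 1 (0.35 log units; beyond the scatter), follows the change (cyano in place of trifluoromethyl on an aromatic carbon). Compound 3 `COc1ccc2sc(NC(=O)c3ccc(C(F)(F)F)cc3)nc2c1` carries a different core, and the difference between the two cores is not broken down here. In this assay compound 3 reaches only a limit of the assay, > 10 ug/mL, and this is the limit described in the limit of > 10 ug/mL in this assay, at which 1 of the 3 values shown sits.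

Compound 4 `COc1ccc2sc(NC(=O)c3ccc(C#N)cc3)nc2c1` is not yet measured in this assay. It stands to compound 3 as compound 1 stands to compound 2: the change is cyano in place of trifluoromethyl on an aromatic carbon, the same change as the one made on the core of compound 2, at the same place on the ring. Among the compounds with values here, only a single measured instance of this change exists, so the expectation for compound 4 rests on that one step. From the step of a 2.3-fold lower number from compound 2 to compound 1 (0.35 log units; beyond the scatter) on the core of compound 2, a step of similar size, an at least 1.2-fold lower number from compound 3 to compound 4 (0.09 log units; that floor lies within the scatter), is expected for compound 4; but because compound 3 gives only the limit > 10 ug/mL, the starting point is itself uncertain, and compound 4 may again sit at the limit rather than yield a number. The estimate for compound 4 in this assay is 8 ug/mL, with a range from 2.5 ug/mL to 30 ug/mL.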

Compound 4, concentration for 50% growth inhibition: > 10 ug/mL
Compound 4: no number, only a limit; the forecaster's own chance of this, stated with the estimate: 45%; middle value at least 1.2-fold (0.09 log units) away from the limit.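

No step can be read between compound 3 and compound 4 in this assay, since both stand only at the same limit of the assay, not at a number: the limit of > 10 ug/mL in this assay, at which 2 of the 4 values shown sit.

The compounds shown leave open whether cyano in place of trifluoromethyl changes growth inhibition on the core of compound 3 in the way it does on the core of compound 2.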